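Urea-to-amide step in a methoxy tetrahydroquinoline series

The compounds below may be only part of what the source reports. "The series", "measured", "known", "first", "only" and "open" are said of these compounds alone.

Measured compounds:
- compound 1, `CCNC(=O)NCC1CCc2c(cccc2OC)N1`: "not determined" (no result reported) in a functional assay on CHO cells with melatonin receptor type 1A (Homo sapiens) as the target, read by GTPgammaS binding, with a stated time of 1 h; on this read-out lower numbers stand for an effect already at smaller amounts and higher numbers for an effect only at larger amounts of compound
- compound 2, `CCNC(=O)NCC1CCc2c(OC)cccc2N1C`: 160 nM
- compound 3, `CCNC(=S)NCC1CCc2ccccc2N1`: 2660 nM

Compound 2 holds the lowest of the two numbers available in this assay. The nearest other entry is compound 3, whose value in this assay stands well above it, a gap beyond the usual scatter; compound 3 differs from compound 2 in more than one place, so the two values only show where each compound stands and do not isolate any single change. Compound 1 is structurally close but carries no number, so it gives no anchor.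

Compound 4, `CCC(=O)NCC1CCc2c(OC)cccc2N1C`, is to be measured in this assay. It differs from compound 2 by ethyl in place of ethylamino on a carbonyl carbon, which means the (ethylcarbamoyl)amino group becomes a propanoylamino group. Among the measured compounds shown here, no measured pair shows this change on its own, so the size of the step is open.

The expectation is that compound 4 gives a lower number than compound 2, a step of moderate size, possibly beyond the scatter, though a result within the scatter of compound 2 is not excluded. The estimated step is a 3.2-fold lower number from compound 2 to compound 4 (0.51 log units; beyond the scatter). Compound 4 is expected at 50 nM, within 10 nM to 250 nM.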

Compound 4, half-maximal effective concentration: 1.7 nM
Beside the measured number, compound 4's estimate is 29-fold (1.47 log units) above it, outside the stated range (below it).
By their numbers in this assay, from the lowest: compound 4; then compound 2; then compound 3.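

In this assay, among the compounds shown here, ethyl in place of ethylamino on a carbonyl carbon gives a 94-fold lower number from compound 2 to compound 4 (1.97 log units; beyond the scatter), the first step that isolates a single change and a large one, well beyond the scatter. This position therefore responds strongly to a small edit: the (ethylcarbamoyl)amino group becomes a propanoylamino group, the hydrogen-bond donor counted on the ethylamino group is gone, and the ethyl group that enters carries none, while the rest of the compound stays the same. No measurement here bears on why the step is so large, so the link between the lost donor and the lower number remains only a coincidence of the two structures.

Open, on these data alone, is whether the gain comes from the loss of the nitrogen itself or from the shorter group on the carbonyl carbon, and whether a methyl, a longer chain such as propyl, or a cyclopropyl group at this place would keep the number near that of compound 4. Also open, as far as these compounds go, is whether the same change has a step of similar size on the core of compound 1 or compound 3.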